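The source may report more compounds than this note shows. Statements on the series, on what has been measured and on what is new or still open speak of the compounds shown alone.

Compound 1 `COc1cc2c(Oc3ccc(NC(=O)c4nnn(-c5ccccc5)c4C)cc3F)ccnc2cc1OCCCN1CCCC1` is one of three compounds with a number in a functional assay on A549 cells (Homo sapiens) for cytotoxicity, read by MTT assay, with a stated time of 72 h (on this read-out higher numbers stand for weaker inhibition and lower numbers for stronger inhibition), where compound 1 gives 90 nM. That places it second highest of the three. Compound 3 `COc1cc2c(Oc3ccc(NC(=O)c4nnn(-c5ccc(F)cc5)c4C(F)(F)F)cc3F)ccnc2cc1OCCCN1CCCC1` gives 80 nM in this assay, which sits within the scatter of the number for compound 1, so the two cannot be told apart. Among the measured compounds shown here, compound 2 `COc1cc2c(Oc3ccc(NC(=O)c4nnn(-c5ccccc5C(F)(F)F)c4C)cc3F)ccnc2cc1OCCCN1CCCC1` gives 160 nM in this assay; the one single-point step among the measured compounds, a 1.8-fold higher number from compound 1 to compound 2 (0.25 log units; within the scatter), also stays within the scatter.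

Compound 4 `COc1cc2c(Oc3ccc(NC(=O)c4nnn(-c5ccccc5)c4C)cc3F)ccnc2cc1OCCCN1CCCCC1` differs from compound 1 in one place: piperidin-1-yl in place of pyrrolidin-1-yl on a saturated chain carbon, three bonds along the chain from an oxygen on an aromatic ring. For the measured compounds named here, no measured step touches this part of the molecule; the one step that is known concerns a trifluoromethyl on an aromatic carbon, and it stays within the scatter. With nothing in the measured set pointing either way, the step of a 1.1-fold higher number from compound 1 to compound 4 (0.05 log units; within the scatter) is expected to stay within the scatter as well. The estimate for compound 4 in this assay is therefore 100 nM, with a range from 45 nM to 220 nM.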

Compound 4, half-maximal inhibitory concentration: 100 nM
For compound 4 middle estimate and measured number coincide at the digits printed, within the range that was stated.
By their numbers in this assay, from the lowest: compounds 3, 1, 4 and 2 (each within the scatter of the next).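

In this assay, among the compounds shown here, the exchange of pyrrolidin-1-yl for piperidin-1-yl on the saturated chain gives a 1.1-fold higher number from compound 1 to compound 4 (0.05 log units; within the scatter), the first step read at this position, as the only earlier step concerned a trifluoromethyl on an aromatic carbon. For this pair, then, the five-membered non-aromatic ring at the end of the chain can give way to the six-membered one without a change that this assay can separate from the scatter, so 3-(piperidin-1-yl)propyl and 3-(pyrrolidin-1-yl)propyl cannot be told apart here. No measurement at hand accounts for this result or reaches beyond this one pair.

The compounds shown leave open whether the position would tolerate a more different amine, such as morpholin-4-yl, 4-methylpiperazin-1-yl or dimethylamino, or a shorter or longer chain between the oxygen and the ring. For the compounds shown here, they also leave open whether the same exchange would stay within the scatter on the trifluoromethyl-bearing compound 2 and compound 3, since the exchange is seen only on the phenyl and methyl substituted triazole of compound 1.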